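The source may hold more compounds than are shown below. What is called first, only, known or untested is meant among the compounds shown, and "the series" means these compounds.

Measured compounds:
compound 1, `COc1cccc(-c2noc(COc3ccc(CCC(=O)O)cc3)n2)c1`: 2670 nM
compound 2, `O=C(O)CCc1ccc(OCc2nc(-c3ccc(Cl)cc3)no2)cc1`: 540 nM
compound 3, `O=C(O)CCc1ccc(OCc2nc(-c3ccc(F)cc3)no2)cc1`: 680 nM

In a functional assay on CHO cells for agonist activity at Free fatty acid receptor 1 (Homo sapiens), read by FLIPR and calcium flux, in the presence of a further agent that is not named here (on this read-out lower numbers stand for an effect already at smaller amounts and higher numbers for an effect only at larger amounts of compound), compound 1 gives 2670 nM, the highest of the three numbers. Compound 2 and compound 3 sit well below it: a 4.9-fold lower number from compound 1 to compound 2 (0.69 log units; beyond the scatter) and a 3.9-fold lower number from compound 1 to compound 3 (0.59 log units; beyond the scatter), while a 1.3-fold higher number from compound 2 to compound 3 (0.10 log units; within the scatter), so the two halogen analogues cannot be told apart.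

Compound 4, `O=C(O)CCc1ccc(OCc2nc(-c3cccc(C(F)(F)F)c3)no2)cc1`, keeps the core of compound 1 and changes only the group on the phenyl ring: trifluoromethyl in place of methoxy on an aromatic carbon. The two measured steps that bear on it both leave the methoxy group and both lower the number by a modest amount, but each also moves the substituent to the para position, whereas in compound 4 the new group stays where the methoxy sat. Going by the values given here, no measured pair separates the change of group from the change of place, so the expectation rests on the two steps from compound 1 alone. A modest step downward is therefore expected for compound 4, a 2.2-fold lower number from compound 1 to compound 4 (0.35 log units; beyond the scatter), with wide room on either side.

Compound 4 is estimated at 1200 nM, in the range 400 nM to 3500 nM.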

Compound 4, half-maximal effective concentration: 1110 nM
Beside the measured number, compound 4's estimate is 1.1-fold (0.03 log units) above it; the measured number falls inside the stated range.
By their numbers in this assay, from the lowest: compounds 2, 3 and 4 (each within the scatter of the next, the first and the last beyond it); then compound 1.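

In this assay, with the group held meta to a large group, trifluoromethyl in place of methoxy gives a 2.4-fold lower number from compound 1 to compound 4 (0.38 log units; beyond the scatter). The earlier steps shown here from compound 1 changed the group and its place together, whereas this one changes the group alone, so a lower number beyond the scatter can be reached here without moving the substituent. Going by these compounds alone, nothing at hand gives a reason for this step, and a methoxy group is the only other group seen at this place, so the comparison rests on a single pair.

Going by these compounds, how much of the steps to compound 2 and compound 3 belongs to the change of group and how much to the change of place remains open. On these data alone, it is also open how a chloro group, a fluoro group, a nitrile or an amine would fare at this same place.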